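This account rests on a few compounds, and the source may have more. Where it says the series, first, only, none or still open, it means among the compounds named here.

Working notes on the series. In a functional assay on MCF7 cells (Homo sapiens) for antiproliferative activity, read by MTT assay, with a stated time of 48 h (a lower number here means a stronger inhibitor, a higher number a weaker inhibitor), compound 1 (`COC(=O)[C@H](CC(C)C)NC(=O)c1ccc(Oc2nc3ccccc3nc2C)cc1`) gives 25500 nM, compound 2 (`CCCCCCCCCCCCNc1nc2ccccc2nc1Oc1ccc(C(=O)N[C@@H](C)C(=O)OC)cc1`) gives 33800 nM and compound 3 (`COC(=O)[C@H](C)NC(=O)c1ccc(Oc2nc3ccccc3nc2NC(C)(C)C)cc1`) gives 38400 nM. These three values lie within the scatter of one another, so compound 3 stands level with the other two.

Compound 4 (`COC(=O)[C@H](CC(C)C)NC(=O)c1ccc(Oc2nc3ccccc3nc2NC(C)(C)C)cc1`) differs from compound 3 by isopropyl in place of hydrogen on a saturated chain carbon, two bonds along the chain from an amide-type nitrogen and a carbonyl carbon. Cut one bond further out, the same difference reads methyl to isobutyl.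

For the measured compounds named here, no measured step covers this change directly. Going by the values given here, the one measured step, a 1.1-fold higher number from compound 2 to compound 3 (0.06 log units; within the scatter), concerns tert-butyl and dodecyl on a nitrogen on an aromatic ring, and it stays within the scatter. Compound 1 also carries the isobutyl group, and its 25500 nM falls in the same range as the other two values. No step beyond the scatter is therefore expected in this assay, and no direction is assigned.

The expected step is a 1.3-fold lower number from compound 3 to compound 4 (0.11 log units; within the scatter). For compound 4 the estimated value is 30000 nM, with an expected range of 14000 nM to 65000 nM.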

Compound 4, half-maximal inhibitory concentration: > 50000 nM
Compound 4 was reported as a limit; the forecaster's own chance of this, stated with the estimate: 10%; middle value at least 1.6-fold (0.22 log units) away from the limit.
By their numbers in this assay, from the lowest: compounds 1, 2 and 3 (each within the scatter of the next). At a limit, above all of these: compound 4.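

In this assay, methyl to isobutyl at this saturated chain carbon, with the (tert-butyl)amino group held, gives an at least 1.3-fold higher number from compound 3 to compound 4 (0.11 log units; that floor lies within the scatter), so this change takes the series out of the measured range and onto a limit. With the isobutyl group held, (tert-butyl)amino in place of methyl on an aromatic carbon gives an at least 1.9-fold higher number from compound 1 to compound 4 (0.29 log units; that floor lies within the scatter); neither floor establishes a step beyond the scatter, and neither excludes a larger one. Compound 4 is the only compound shown that is reported as a limit: the limit of > 50000 nM in this assay, at which 1 of the 4 values shown sits.

Going by these compounds, the true size of both steps remains open, as does the effect of the isobutyl group when dodecyl sits on the nitrogen. Also open, on these data alone, is whether benzyl at this chain carbon, or a carboxylic acid in place of the methyl ester, would give a value inside the measured range.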